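This account rests on a few compounds, and the source may have more. Where it says the series, first, only, none or still open, it means among the compounds named here.

Compound 2, `CCCNC(=S)NCCC(O)c1ccccc1N`, is the starting point here. Within the data shown here, in an assay for inhibition of Nitric oxide synthase, inducible (Homo sapiens), read by scintillation counting, with a stated time of 30 min, tested at 1 mM (a lower number here means less inhibition, a higher number more inhibition at the concentration tested (going by the name of the read-out)), compound 2 gives 31.1%, the higher of the two numbers measured so far. Among the measured compounds shown here, the only other measured compound, compound 1, `CCNC(=S)NCCC(O)c1ccccc1N`, gives 19.4% in this assay. One step connects them: a number 11.7 percentage points higher from compound 1 to compound 2 (beyond the scatter), a methyl in place of hydrogen on a saturated chain carbon, two bonds along the chain from an amide-type nitrogen.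

Compound 3, `CCCNC(=S)NCCC(O)c1cc(OC)ccc1N`, has not been measured yet. Compared with compound 2 it shows (methoxy in place of hydrogen on an aromatic carbon).

For the measured compounds named here, the single measured step concerns the chain, not the aromatic ring, so it does not bear on this change; no measured step touches the ring at all. With nothing to point either way, the expectation for the step from compound 2 to compound 3 is no change beyond the scatter, a number 0.1 percentage points lower from compound 2 to compound 3 (within the scatter). Compound 3 is therefore estimated at 31%, within a range from 10% to 55%.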

Compound 3, a percentage reported as inhibition, at one concentration (the size of the read-out at that concentration, not a potency): 25.4%
Beside the measured number, compound 3's estimate is 5.6 percentage points above it; low and high end bracket the measured number.
By their numbers in this assay, from the lowest: compounds 1, 3 and 2 (each within the scatter of the next, the first and the last beyond it).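

Among these compounds, this is the first measured change on the aromatic ring of this series. In this assay, methoxy in place of hydrogen on the aromatic carbon meta to a large group and para to an amino group gives a number 5.7 percentage points lower from compound 2 to compound 3 (within the scatter), so at this position the added oxygen and carbon produce no difference that can be told apart from the usual scatter, unlike the chain step, a number 11.7 percentage points higher from compound 1 to compound 2 (beyond the scatter), which lies beyond it. No evidence here bears on this result.

Going by these compounds, a single substituent at one ring position says little about the ring as a whole, so it remains open whether a larger group such as ethoxy, or a different one such as chlorine or hydroxyl, would behave in the same way. On these data alone, it is equally open whether methoxy on another carbon of the ring would give a number beyond the scatter.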